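This account rests on a few compounds, and the source may have more. Where it says the series, first, only, none or still open, it means among the compounds named here.

Measured so far in an ADME assay on Vero cells (Chlorocebus sabaeus) for cytotoxicity, read by neutral red uptake, tested at 1575 ug/mL; on this read-out lower numbers stand for a stronger effect and higher numbers for a weaker effect at the one concentration tested:

compound 1 `COc1ccccc1C1SCC(=O)N1CCN1CCCCC1` gives 17%
compound 2 `O=C1CSC(c2ccccc2[N+](=O)[O-])N1CCN1CCCCC1` gives 24%
compound 3 `O=C1CSC(c2cccc(F)c2)N1CCN1CCCCC1` gives 17%

Where compound 3 stands: in this assay compound 3 sits level with compound 1 at the digits read, and these two share the low end of the three numbers. Compound 2 is the number furthest from compound 3, yet the gap lies within the usual scatter, so the three values describe one narrow band rather than a ranking.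

Within the data shown here, the single one-place step measured on the series, a number 7 percentage points higher from compound 1 to compound 2 (within the scatter), exchanges a group on the aromatic ring and stays within the scatter.

Compound 4 `O=C1CSC(c2ccccc2Cl)N1CCN1CCCCC1` is not yet measured. It differs from compound 3 as follows: 2-chlorophenyl in place of 3-fluorophenyl on a saturated ring carbon.

Bearing on this step: only a number 7 percentage points higher from compound 1 to compound 2 (within the scatter) touches the aromatic ring at all, and it shows no movement beyond the scatter. Among the measured compounds shown here, no measured pair exchanges one halogen on the phenyl for another, so the expectation rests on the flatness of the band, because a number 7 percentage points higher from compound 1 to compound 2 (within the scatter) is the sole guide and it is small. The step expected for this assay is therefore none beyond the scatter, which a number 2 percentage points higher from compound 3 to compound 4 (within the scatter) expresses.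

Estimated value for compound 4 in this assay: 19%, expected to fall between 8% and 32%.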

Compound 4, a percentage reported as activity, at one concentration (the size of the read-out at that concentration, not a potency): 16%
Beside the measured number, compound 4's estimate is 3 percentage points above it; the measured number falls inside the stated range.
By their numbers in this assay, from the lowest: compounds 4, 1, 3 and 2 (each within the scatter of the next).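

Among these compounds, exchanging 3-fluorophenyl for 2-chlorophenyl on the saturated ring carbon, next to the ring nitrogen and next to the ring sulfur, reads as a number 1 percentage points lower from compound 3 to compound 4 (within the scatter) in this assay and is the first measured step that changes both the halogen and the phenyl substitution. Chloro on an aromatic carbon also joins the earlier comparison of substituents, with a number 8 percentage points lower from compound 2 to compound 4 (within the scatter) against the nitro group and a number 1 percentage points lower from compound 1 to compound 4 (within the scatter) against the methoxy group, so all four compounds now remain in one narrow band with none going against it. No available measurement accounts for this flatness.

The compounds shown leave open whether a group of another kind on the phenyl, such as an amine or a carboxylic acid, would produce a step beyond the scatter in this assay at the one concentration tested. They also leave open whether a change outside the aromatic ring, such as a longer chain on the ring nitrogen, would separate any compound from this band.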